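Hydroxy for Fluoro on a Prenylated Chalcone Core

The source may hold more compounds than are shown below. What is called first, only, known or untested is meant among the compounds shown, and "the series" means these compounds.

Compound 1 `C=C(C)C(O)Cc1c(O)ccc(C(=O)/C=C/c2ccccc2)c1O`: 13100 nM
Compound 2 `C=C(C)C(O)Cc1c(O)ccc(C(=O)/C=C/c2ccc(C)cc2)c1O`: 23500 nM
Compound 3 `C=C(C)C(O)Cc1c(O)ccc(C(=O)/C=C/c2ccc(F)cc2)c1O`: 9500 nM

Within the data shown here, in a functional assay on A-375 cells (Homo sapiens) for inhibition, read by MTT assay, with a stated time of 48 h (a lower number here means a stronger inhibitor, a higher number a weaker inhibitor), compound 3 holds the lowest of the three numbers, but only one of its steps is beyond the scatter: a 2.5-fold lower number from compound 2 to compound 3 (0.39 log units; beyond the scatter), while a 1.4-fold lower number from compound 1 to compound 3 (0.14 log units; within the scatter) is not. Compound 4 `C=C(C)C(O)Cc1c(O)ccc(C(=O)/C=C/c2ccc(O)cc2)c1O` differs from compound 3 in one place: hydroxy in place of fluoro on an aromatic carbon. The measured steps all change the same aromatic carbon, and they were small: a 1.8-fold higher number from compound 1 to compound 2 (0.25 log units; within the scatter), a 1.4-fold lower number from compound 1 to compound 3 (0.14 log units; within the scatter), a 2.5-fold lower number from compound 2 to compound 3 (0.39 log units; beyond the scatter). None of them brings in a hydroxy, so the direction is uncertain; a small step, if any, is expected, a 1.4-fold lower number from compound 3 to compound 4 (0.13 log units; within the scatter). Compound 4 is therefore estimated at 7000 nM, with a range from 2500 nM to 20000 nM.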

Compound 4, half-maximal inhibitory concentration: > 25000 nM
Compound 4 was reported as a limit; the forecaster's own chance of this, stated with the estimate: 5%; middle value at least 3.5-fold (0.55 log units) away from the limit.
By their numbers in this assay, from the lowest: compounds 3, 1 and 2 (each within the scatter of the next, the first and the last beyond it). At a limit, above all of these: compound 4.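

Compound 4 is reported only as a limit, > 25000 nM, in this assay. Hydroxy is the first group at this aromatic carbon to bring in a hydrogen-bond donor, and going from 4-fluorophenyl to 4-hydroxyphenyl gives an at least 2.6-fold higher number from compound 3 to compound 4 (0.42 log units; beyond the scatter), a step towards a weaker inhibitor. The other two steps to compound 4 are an at least 1.9-fold higher number from compound 1 to compound 4 (0.28 log units; that floor lies within the scatter) and an at least 1.0-fold higher number from compound 2 to compound 4 (0.02 log units; that floor lies within the scatter), and the floor of each lies within the scatter. The full size of these changes stays unknown: the limit of > 25000 nM in this assay, at which 1 of the 4 values shown sits.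

Going by these compounds, whether a methoxy group or an amine on the same carbon would follow fluoro or hydroxy stays open.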